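A few compounds are considered here, and "the series" means these few. Any claim that something is new, unique, unknown or untested is made for them only; others in the source may bear on it.

Of the compounds shown here, two have been measured in a functional assay on U-87MG ATCC cells for antiproliferative activity against U-87 MG (Homo sapiens), read by MTT assay, with a stated time of 48 h, tested at 50 uM; a higher number here means a weaker effect of the compound at the concentration tested, a lower number a stronger effect. Compound 1, `Cc1nc(-c2ccccc2)sc1C(=O)CSc1nc(N)c(C#N)c(-c2ccc(Cl)cc2)n1`, gives 44.3% in this assay. Compound 2, `COc1ccc(-c2nc(SCC(=O)c3sc(-c4ccc(Cl)cc4)nc3C)[nH]c(=O)c2C#N)cc1OC`, gives 59.8% in this assay, the higher of the two numbers; its nearest neighbour, compound 1, sits lower by a gap beyond the usual scatter, so at this concentration compound 2 shows the weaker effect of the pair. Within the data shown here, no single-change step between measured compounds can be drawn, as compound 1 and compound 2 differ in more than one place.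

Compound 3, `Cc1nc(-c2ccc(Cl)cc2)sc1C(=O)CSc1nc(-c2ccc(Cl)cc2)c(C#N)c(=O)[nH]1`, has not yet been measured. It differs from compound 2 in one place: 4-chlorophenyl in place of 3,4-dimethoxyphenyl on an aromatic carbon. Compound 1 also carries a 4-chlorophenyl group and gives 44.3%, the lower number, but its core differs in other places too, so that comparison is only a loose guide. For compound 3 the expected step is a number 7.8 percentage points lower from compound 2 to compound 3 (within the scatter), a modest move toward a stronger effect that may not exceed the scatter. Compound 3 is therefore estimated to give 52% in this assay, within a range from 35% to 70%.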

Compound 3, a percentage reported as activity, at one concentration (the size of the read-out at that concentration, not a potency): 60%
Beside the measured number, compound 3's estimate is 8 percentage points below it, within the range that was stated.
By their numbers in this assay, from the lowest: compound 1; then compounds 2 and 3 (each within the scatter of the next).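

In this assay, among these compounds, placing 4-chlorophenyl instead of 3,4-dimethoxyphenyl on the aromatic carbon ortho to a cyano group gives a number 0.2 percentage points higher from compound 2 to compound 3 (within the scatter), the first comparison in this set that isolates a single change. At this position, on this core, the two groups cannot be told apart in this read-out, even though one carries oxygen atoms and hydrogen-bond acceptors and the other carries a chlorine and no acceptors, so the 4-chlorophenyl group alone does not separate compound 3 from compound 2. No measurement offered here accounts for the two groups reading alike.

Still open, on these data alone, is whether an amine or a carboxylic acid on this phenyl ring, or a methyl group in place of the whole ring, would move the number beyond the scatter. Also open, as far as these compounds go, is whether compound 2 and compound 3 would still match in a full potency measurement, and this read-out reports the effect at only one concentration.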